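This account rests on a few compounds, and the source may have more. Where it says the series, first, only, none or still open, it means among the compounds named here.

Measured compounds:
- Compound 1, `CC1(C)S[C@@H]2/C(=C\C(=O)c3ccc4ccccc4c3)C(=O)N2[C@H]1C(=O)OC(c1ccccc1)c1ccccc1`, gives 19500 nM in a functional assay on OE19 cells (Homo sapiens) for cytotoxicity, read by MTT assay, with a stated time of 48 h; on this read-out lower numbers stand for stronger inhibition and higher numbers for weaker inhibition.
- Compound 2, `CC1(C)S[C@@H]2/C(=C\C(=O)c3ccco3)C(=O)N2[C@H]1C(=O)OC(c1ccccc1)c1ccccc1`, gives 54300 nM in this assay.
- Compound 3, `CCOC(=O)/C=C1/C(=O)N2[C@@H]1SC(C)(C)[C@@H]2C(=O)OC(c1ccccc1)c1ccccc1`, gives 11200 nM in this assay.

Compound 3 has the lowest of the three numbers in this assay, but its gap to compound 1, a 1.7-fold lower number from compound 1 to compound 3 (0.24 log units; within the scatter), is within the scatter, so the two cannot be ordered; only the gap to compound 2, a 4.8-fold lower number from compound 2 to compound 3 (0.69 log units; beyond the scatter), is clearly beyond it. Compound 4, `CC1(C)S[C@@H]2/C(=C\C(=O)OCc3ccccc3)C(=O)N2[C@H]1C(=O)OC(c1ccccc1)c1ccccc1`, is not yet measured. It differs from compound 3 by phenyl in place of methyl on a saturated chain carbon bound to an oxygen next to a carbonyl group, so the ethyl ester becomes a benzyl ester while the rest of the shared core stays the same.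

Going by the values given here, no measured step tests a change at this place. The steps that exist, a 2.8-fold higher number from compound 1 to compound 2 (0.44 log units; beyond the scatter) and a 4.8-fold lower number from compound 2 to compound 3 (0.69 log units; beyond the scatter), swap the group on the carbonyl carbon itself, and even those move the numbers only modestly. Among the compounds with values here, with no direct precedent, the expected step in this assay from compound 3 to compound 4 is estimated as a 1.2-fold lower number from compound 3 to compound 4 (0.09 log units; within the scatter), which may well lie within the scatter. Compound 4 is therefore expected to give about 9000 nM, in a range from 3500 nM to 25000 nM.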

Compound 4, half-maximal inhibitory concentration: 8200 nM
Beside the measured number, compound 4's estimate is 1.1-fold (0.04 log units) above it; measured number inside the range.
By their numbers in this assay, from the lowest: compounds 4, 3 and 1 (each within the scatter of the next, the first and the last beyond it); then compound 2.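

Going by these compounds alone, replacing methyl with phenyl on the saturated chain carbon bound to an oxygen next to a carbonyl group is the first change tested at this place, and in this assay it gives a 1.4-fold lower number from compound 3 to compound 4 (0.14 log units; within the scatter), so this position accepts a six-membered aromatic ring without a change that can be told from scatter. The benzyloxy group also stands clearly apart from both ketone-type groups, with a 6.6-fold lower number from compound 2 to compound 4 (0.82 log units; beyond the scatter) and a 2.4-fold lower number from compound 1 to compound 4 (0.38 log units; beyond the scatter), whereas the ethoxy group could not be separated from naphthalen-2-yl, although compound 3 and compound 4 themselves cannot be ordered. No measurement is available to explain these numbers.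

Methyl and phenyl are the only two ends shown at this place, so it remains open how a longer chain ending in phenyl, or a chain ending in an amine, would behave. Also open, as far as these compounds go, is what a free carboxylic acid in place of the ester would give.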